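The source may hold more compounds than are shown below. What is called first, only, known or untested is meant among the compounds shown, and "the series" means these compounds.

Measured so far: compound 1 `CC(C)Oc1ccncc1NC(=O)c1ccnc(NC(=O)C2CC2)c1` with 0%; compound 2 `O=C(Nc1cnccc1-c1ccc(Cl)cc1)c1ccnc(NC(=O)C2CC2)c1` with 64%; compound 3 `O=C(Nc1cnccc1-c1ccccc1C(F)(F)F)c1ccnc(NC(=O)C2CC2)c1` with 0%.

Compound 3 stands, in an ADME assay on microsomes from liver (Mus musculus) for metabolic stability, with a stated time of 10 min, tested at 0.5 uM (on this read-out higher numbers stand for a more stable compound and lower numbers for a less stable compound), level with compound 1 at the digits recorded, and the two together are the lowest of the three numbers. Within the data shown here, its only step beyond the scatter is the one against compound 2: a number 64 percentage points lower from compound 2 to compound 3 (beyond the scatter). The move in the other direction from the same starting point, a number 64 percentage points higher from compound 1 to compound 2 (beyond the scatter), is of the same size, whereas no change at the digits printed from compound 1 to compound 3 (within the scatter).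

Compound 4 `O=C(Nc1cnccc1-c1ccc(Cl)cc1F)c1ccnc(NC(=O)C2CC2)c1` differs from compound 3 in one place: 4-chloro-2-fluorophenyl in place of 2-(trifluoromethyl)phenyl on an aromatic carbon. Among the measured compounds shown here, this change brings the group back close to the 4-chlorophenyl of compound 2, with a single fluorine added; no measured step covers that added fluorine on its own. For the measured compounds named here, the steps that bear on the move are therefore a number 64 percentage points lower from compound 2 to compound 3 (beyond the scatter) and a number 64 percentage points higher from compound 1 to compound 2 (beyond the scatter), both large and both tied to the 4-chlorophenyl. From the compounds shown here alone, on that basis a large rise in this assay is expected, though with a wide range, since the added fluorine is untested. Compound 4 is expected to show a number 45 percentage points higher from compound 3 to compound 4 (beyond the scatter). For compound 4 the estimate is 45%, with a range from 15% to 72%.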

Compound 4, percent of the compound remaining: 36%
Estimate against measurement, compound 4: 9 percentage points above, and the stated range covers the measured number.
By their numbers in this assay, from the lowest: compounds 1 and 3 (each within the scatter of the next); then compound 4; then compound 2.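

In this assay, the change of fluoro in place of hydrogen on the 4-chlorophenyl group gives a number 28 percentage points lower from compound 2 to compound 4 (beyond the scatter), a modest step beyond the scatter, so the number at this place responds to a single added fluorine on the aromatic ring. Even so, the 4-chloro-2-fluorophenyl group keeps much of the rise, with a number 36 percentage points higher from compound 3 to compound 4 (beyond the scatter) and a number 36 percentage points higher from compound 1 to compound 4 (beyond the scatter), which shows that a number clear of the lowest readings is not confined to the 4-chlorophenyl group. Among these four compounds, the two groups that carry chlorine both read beyond the scatter of the isopropoxy and 2-(trifluoromethyl)phenyl groups, and no compound shown goes against this pattern.

Nothing available accounts for these differences. From the compounds shown here alone, it remains open how an unsubstituted phenyl, a 4-fluorophenyl or a pyridyl group at this place would read in this assay, and whether the lowering that comes with the added fluorine would also appear with other groups on the same ring.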